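A few compounds are considered here, and "the series" means these few. Any claim that something is new, unique, unknown or untested is made for them only; others in the source may bear on it.

Of the compounds shown here, three of a shared core have been measured in an assay on isolated protein for inhibition of Dihydrofolate reductase (Mus musculus); on this read-out lower numbers stand for lower potency and higher numbers for higher potency (the scale is a negative logarithm). Compound 1 `CC1(C)N=C(N)N=C(N)N1c1ccc(OCCCCOc2ccc(S(=O)(=O)F)cc2)c(Cl)c1` gives 7.57. Compound 3 `CC1(C)N=C(N)N=C(N)N1c1ccc(CCC(=O)Nc2cccc(S(=O)(=O)F)c2)cc1` gives 7.74. Compound 2 `CC1(C)N=C(N)N=C(N)N1c1ccc(OCc2cc(Cl)ccc2S(=O)(=O)F)c(Cl)c1` gives 7.27, the lowest of the three numbers; compound 1 sits within the scatter of it, while compound 3 lies beyond the scatter. Compound 4 `CC1(C)N=C(N)N=C(N)N1c1ccc(OCc2ccccc2S(=O)(=O)F)c(Cl)c1` follows from compound 2 by a single change: hydrogen in place of chloro on an aromatic carbon. For the measured compounds named here, no measured pair shows what such a change does on this core, so no step beyond the scatter is expected in either direction. Compound 4 is therefore expected to stay near compound 2, with an estimated value of 7.3 (range 6.8 to 7.8), an expected step of a number 0.03 log units higher from compound 2 to compound 4 (within the scatter).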

Compound 4, logarithm of the reciprocal of the active concentration, log(1/C): 7.43
The estimate for compound 4 lay 0.13 log units below the measured number; low and high end bracket the measured number.
By their numbers in this assay, from the lowest: compounds 2, 4, 1 and 3 (each within the scatter of the next, the first and the last beyond it).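

For the compounds shown here, on the shared core, hydrogen in place of chloro para to a fluorosulfonyl group gives the first step that can be read in this assay (a step of a number 0.16 log units higher from compound 2 to compound 4 (within the scatter)). This single pair shows that the chloro at this position can be lost without a step beyond the scatter. Nothing at hand bears on the reason for this result. As far as these compounds go, whether an amine, a methoxy group or a carboxylic acid at this aromatic carbon would behave like hydrogen remains open, as does whether the same change would give a similar step on another compound of this core.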